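Trifluoromethyl for methoxy on the diaryl urea series

This account rests on a few compounds, and the source may have more. Where it says the series, first, only, none or still open, it means among the compounds named here.

Compound 2 `COc1cc(Nc2cc(NC(=O)Nc3c(Cl)cccc3Cl)ncn2)cc(OC)c1` gives 90% in a functional assay on PC-9 cells (Homo sapiens) for inhibition, read by MTT assay, with a stated time of 48 h, tested at 10 uM (on this read-out lower numbers stand for less inhibition and higher numbers for more inhibition at the one concentration tested (going by the name of the read-out)), the higher of the two numbers in hand; compound 1 `COc1cc(NC(=O)Nc2cc(Nc3ccc(C)c(C)c3)ncn2)cc(OC)c1` gives 66%, a gap beyond the scatter. Compound 3 `COc1cc(Nc2cc(NC(=O)Nc3c(Cl)cccc3Cl)ncn2)cc(C(F)(F)F)c1` is not yet measured. It differs from compound 2 by trifluoromethyl in place of methoxy on an aromatic carbon, on an aromatic carbon of a six-membered aromatic ring of carbon only, meta to a methoxy group. For the measured compounds named here, no measured step of this kind exists in the set, so the expectation rests on compound 2 alone; a change within the scatter, or a small loss, seems most likely. Compound 3 is expected to give 84%, with a range of 65% to 96%. The expected step in this assay is a number 6 percentage points lower from compound 2 to compound 3 (within the scatter).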

Compound 3, a percentage reported as inhibition, at one concentration (the size of the read-out at that concentration, not a potency): 88.5%
Beside the measured number, compound 3's estimate is 4.5 percentage points below it; the range from low to high includes it.
By their numbers in this assay, from the lowest: compound 1; then compounds 3 and 2 (each within the scatter of the next).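

In this assay this position takes trifluoromethyl in place of methoxy with a number 1.5 percentage points lower from compound 2 to compound 3 (within the scatter), so the read-out at the one concentration tested does not depend on this methoxy. The swap removes a hydrogen-bond acceptor and brings in more heavy atoms, yet the two numbers stay within the scatter. Nothing in hand explains this result.

From the compounds shown here alone, whether an amine or a carboxylic acid on this aromatic carbon would also hold the number remains open. So does whether the remaining methoxy group can be replaced in the same way.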